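The source may report more compounds than this note shows. Statements on the series, on what has been measured and on what is new or still open speak of the compounds shown alone.

Working notes on the series. Compound 3 `COc1ccc(C(=O)c2cccc(Cl)c2)cc1OC(=O)CCC(=O)OC[C@@H]1C=C[C@H](n2cc(C)c(=O)[nH]c2=O)O1` gives 11100 nM in a functional assay on HepG2 cells (Homo sapiens) for antiproliferative activity, read by MTT assay, with a stated time of 48 h (a lower number here means a stronger inhibitor, a higher number a weaker inhibitor), the second highest of the three numbers measured. Going by the values given here, compound 1 `COc1cccc(C(=O)c2ccc(OC)c(OC(=O)CCC(=O)OC[C@@H]3C=C[C@H](n4cc(C)c(=O)[nH]c4=O)O3)c2)c1` gives 3150 nM; the step of a 3.5-fold higher number from compound 1 to compound 3 (0.55 log units; beyond the scatter) is the only single-point change measured so far. Compound 2 `COc1ccc(C(=O)c2ccc(F)cc2)cc1OCC(=O)OC[C@@H]1C=C[C@H](n2cc(C)c(=O)[nH]c2=O)O1` differs from compound 3 in more than one place; in this assay compound 2 gives 38000 nM, so its value is noted without a step. Compound 4 `COc1ccc(C(=O)c2ccc([N+](=O)[O-])cc2)cc1OC(=O)CCC(=O)OC[C@@H]1C=C[C@H](n2cc(C)c(=O)[nH]c2=O)O1` carries 4-nitrophenyl in place of 3-chlorophenyl on a carbonyl carbon. Among the compounds with values here, no measured step covers this kind of swap on the aryl carbonyl; the one single-point step, a 3.5-fold higher number from compound 1 to compound 3 (0.55 log units; beyond the scatter), was modest and raised the number. The step of a 1.3-fold higher number from compound 3 to compound 4 (0.10 log units; within the scatter) is therefore expected to be small, with its direction uncertain. Compound 4 is estimated at 14000 nM, within 5000 nM to 40000 nM.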

Compound 4, half-maximal inhibitory concentration: 24000 nM
For compound 4 the middle estimate is 1.7-fold (0.23 log units) below the measured one, and the stated range covers the measured number.
By their numbers in this assay, from the lowest: compound 1; then compound 3; then compounds 4 and 2 (each within the scatter of the next).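

On a carbonyl carbon, 4-nitrophenyl in place of 3-chlorophenyl gives a 2.2-fold higher number from compound 3 to compound 4 (0.33 log units; beyond the scatter) in this assay. The wider swap from 3-methoxyphenyl gives a 7.6-fold higher number from compound 1 to compound 4 (0.88 log units; beyond the scatter), so among compounds 1, 3 and 4 this position separates all three aryl groups, with compound 1 lowest. Nothing measured here bears on why the number rises.

The swap to 4-nitrophenyl changes both the group and its ring position, and these remain unseparated. A 3-nitrophenyl or 4-aminophenyl group on the same carbonyl carbon would help to tell them apart.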